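This account rests on a few compounds, and the source may have more. Where it says the series, first, only, none or still open, it means among the compounds named here.

Measured so far in a functional assay on HT-1080 cells (Homo sapiens) for cytotoxicity, read by MTT assay, with a stated time of 72 h; a higher number here means a weaker inhibitor, a lower number a stronger inhibitor:
compound 1 `COc1ccccc1/C=C1\CCC/C(=C\c2cccc(OC)c2OC)C1=O` — 14100 nM
compound 2 `COc1ccc(/C=C2\CCC/C(=C\c3ccccc3Cl)C2=O)cc1OC` — 6800 nM

Compound 2 stands at the lowest number of the two; compound 1 is the nearest, at a higher number beyond the scatter. Compound 3 `COc1cc(/C=C2\CCC/C(=C\c3ccc(OC)c(OC)c3)C2=O)ccc1O` is not yet measured. Relative to compound 2 the change is 4-hydroxy-3-methoxyphenyl in place of 2-chlorophenyl on a double-bonded chain carbon bound to a double-bonded ring carbon. Going by the values given here, no step between two measured compounds tracks this change, so the size is uncertain; the expectation is a modest move toward a higher number, a 1.5-fold higher number from compound 2 to compound 3 (0.17 log units; within the scatter), though a step within the scatter would not surprise. For compound 3 the estimate in this assay is 10000 nM, within 4000 nM to 25000 nM.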

Compound 3, half-maximal inhibitory concentration: 4600 nM
Compound 3: the middle estimate sits 2.2-fold (0.34 log units) above what was measured, within the range that was stated.
By their numbers in this assay, from the lowest: compounds 3 and 2 (each within the scatter of the next); then compound 1.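

In this assay, 4-hydroxy-3-methoxyphenyl in place of 2-chlorophenyl on a double-bonded chain carbon bound to a double-bonded ring carbon gives a 1.5-fold lower number from compound 2 to compound 3 (0.17 log units; within the scatter). In this single pair, the place therefore tolerates a swap from a group with no hydrogen-bond donors or acceptors to one that has both, without a step beyond the scatter. No available evidence bears on this result. Still open, as far as these compounds go, is how a phenyl ring carrying an amine or a carboxylic acid would read at this place. The separate contributions of the hydroxy and methoxy groups also remain unresolved.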